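A few compounds are considered here, and "the series" means these few. Any claim that something is new, unique, unknown or untested is made for them only; others in the source may bear on it.

Three members of this series have been run in a functional assay on the whole organism with Mus musculus as the target, in the maximal electroshock model, at a dose of 50 mg/kg by the oral route; a higher number here means more inhibition at the dose given (going by the name of the read-out), a lower number less inhibition. Compound 1, `OC1CCN(CCCCOc2ccccc2/C=C/c2ccccc2)CC1`, gives 0%. Compound 2, `CC(=O)N1CCN(CCCCOc2ccccc2/C=C/c2ccccc2)CC1`, gives 0%. Compound 3, `COC(=O)C1CCCN(CCCCOc2ccccc2/C=C/c2ccccc2)C1`, gives 0%. Within the data shown here, the only step worked out among them, no change at the digits printed from compound 1 to compound 2 (within the scatter), exchanges the saturated ring at the end of the chain for another and leaves the read-out where it was. Among the measured compounds shown here, compound 3 stands level with compounds 1 and 2 at the digits recorded; no step is worked out from compound 3 to either, and the values themselves show no difference between them.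

Compound 4, `CC1CCCN(CCCCOc2ccccc2/C=C/c2ccccc2)C1`, differs from compound 3 by methyl in place of methoxycarbonyl on a saturated ring carbon. For the measured compounds named here, no measured step alters a group on this ring carbon, so the change is untested. What the series does show is that three different saturated rings at the end of the chain all give no inhibition at this dose, and a smaller substituent on the ring of compound 3 gives no ground to expect a departure from that. The expected step is therefore no change at the digits printed from compound 3 to compound 4 (within the scatter), no change beyond the scatter. For compound 4 the expected value is 0%, with a range from 0% to 10%.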

Compound 4, a percentage reported as inhibition, in the whole organism at one dose (the size of the read-out at that dose, not a potency): 12.5%
Compound 4: middle estimate off by 12.5 percentage points, on the low side, outside the stated range (above it).
By their numbers in this assay, from the lowest: compounds 1, 2 and 3 (each within the scatter of the next); then compound 4.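

Among these compounds, this ring carbon, two ring bonds from the ring nitrogen, is the first place where a change moves the read-out in this assay and methyl in place of methoxycarbonyl gives a number 12.5 percentage points higher from compound 3 to compound 4 (beyond the scatter) as a modest step beyond the scatter. The end of the chain is therefore not indifferent to what it carries, as 3-methylpiperidin-1-yl also stands apart from the other two end groups with a number 12.5 percentage points higher from compound 2 to compound 4 (beyond the scatter) and with a number 12.5 percentage points higher from compound 1 to compound 4 (beyond the scatter) while compound 1, compound 2 and compound 3 remain level with one another. Nothing at hand separates the loss of methoxycarbonyl from the arrival of methyl as the source of the rise, and no measurement accounts for it.

The compounds shown leave open how the number responds with hydrogen, ethyl, hydroxymethyl or a carboxylic acid on this same ring carbon, which would show whether the rise follows the methyl or only the absence of the ester. Among the compounds shown here, also open is whether 3-methylpiperidin-1-yl keeps its inhibition on a shorter or longer chain than the one in compound 4.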